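The source may hold more compounds than are shown below. What is called first, only, known or untested is meant among the compounds shown, and "the series" means these compounds.

In a functional assay on NCI-H460 cells (Homo sapiens) for cytotoxicity, read by resazurin assay, with a stated time of 72 h (a lower number here means a stronger inhibitor, a higher number a weaker inhibitor), compound 1 `COc1cc(/C=C/C(=O)OCCCCCCO[N+](=O)[O-])ccc1O` gives only a limit, > 50000 nM. Compound 2 `O=C(/C=C/c1ccc(OCCCCCCO[N+](=O)[O-])c(O)c1)OCCCCCCO[N+](=O)[O-]` also gives only a limit, > 50000 nM. Its standing is therefore (the limit of > 50000 nM in this assay, at which 2 of the 2 values shown sit), and no numerical potency can be assigned to it. Compound 3 `COc1cc(/C=C/C(=O)OCCCCCCO[N+](=O)[O-])ccc1OCCCCCCO[N+](=O)[O-]` differs from compound 2 in one place, methyl in place of hydrogen on an oxygen on an aromatic ring, or hydroxy to methoxy. The estimated a number no higher from compound 2 to compound 3 (the limit leaves the size open) is expected to stay within the scatter, in neither direction. For compound 3, the expected value in this assay is 50000 nM, with an estimated range of 25000 nM to 100000 nM.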

Compound 3, half-maximal inhibitory concentration: > 50000 nM
Compound 3 was reported as a limit; the forecaster's own chance of this, stated with the estimate: 85%; the middle value lies on the limit itself.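

No step can be read among compound 1, compound 2 and compound 3, because each is reported only as a limit: the limit of > 50000 nM in this assay, at which 3 of the 3 values shown sit. The compounds shown leave open how strongly any of the three acts and whether either replacement on the aromatic oxygen changes that.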